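Cyclopropyl to cyclobutyl on the chloro core

A few compounds are considered here, and "the series" means these few. Any claim that something is new, unique, unknown or untested is made for them only; others in the source may bear on it.

Measured so far in an ADME assay on Vero cells (Chlorocebus sabaeus) for cytotoxicity, read by CellTiter-Glo, with a stated time of 72 h; a higher number here means that more compound is tolerated, a lower number that less compound is tolerated:
Compound 1, `[O-][n+]1nc(NC2CC2)[n+]([O-])c2ccccc21`, gives 21 ug/mL.
Compound 2, `[O-][n+]1nc(NC2CCC2)[n+]([O-])c2ccccc21`, gives 8.9 ug/mL.
Compound 3, `[O-][n+]1nc(NC2CC2)[n+]([O-])c2ccc(Cl)cc21`, gives 1.3 ug/mL.

Compound 4, `[O-][n+]1nc(NC2CCC2)[n+]([O-])c2ccc(Cl)cc21`, remains to be measured. Two changes have been seen so far. The change from compound 1 to compound 2 is cyclobutyl in place of cyclopropyl on a nitrogen on an aromatic ring; it produced a 2.4-fold lower number from compound 1 to compound 2 (0.37 log units; beyond the scatter). The two cores differ by chloro in place of hydrogen on an aromatic carbon, and this brought a 16-fold lower number from compound 1 to compound 3 (1.21 log units; beyond the scatter), the larger of the two steps, leaving compound 3 with the lowest number of the three. Compound 4 carries the same change as compound 2, namely (cyclobutyl in place of cyclopropyl on a nitrogen on an aromatic ring), but on the chloro core. The step from compound 3 to compound 4 is expected to be about a 2.4-fold lower number from compound 3 to compound 4 (0.37 log units; beyond the scatter) in this assay, since the same change is the only basis available and it was modest before. Compound 4 is therefore estimated at 0.55 ug/mL, between 0.25 ug/mL and 1.3 ug/mL, because a 2.4-fold lower number from compound 1 to compound 2 (0.37 log units; beyond the scatter).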

Compound 4, half-maximal cytotoxic concentration: 1.6 ug/mL
Estimate against measurement, compound 4: 2.9-fold (0.46 log units) below, and the stated range ends below it.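

In this assay, cyclobutyl in place of cyclopropyl on the chloro core gives a 1.2-fold higher number from compound 3 to compound 4 (0.09 log units; within the scatter), so the step seen without chloro does not carry over: the same change on two cores in this assay, a 2.4-fold lower number (0.37 log units; beyond the scatter) from compound 1 to compound 2 and a 1.2-fold higher number (0.09 log units; within the scatter) from compound 3 to compound 4, 2.9-fold (0.46 log units) apart, beyond the scatter of two such steps. Read the other way, chloro in place of hydrogen still gives a 5.6-fold lower number from compound 2 to compound 4 (0.75 log units; beyond the scatter) on the cyclobutyl side, a smaller step than on the cyclopropyl side: the same change on two cores in this assay, a 16-fold lower number (1.21 log units; beyond the scatter) from compound 1 to compound 3 and a 5.6-fold lower number (0.75 log units; beyond the scatter) from compound 2 to compound 4, 2.9-fold (0.46 log units) apart, beyond the scatter of two such steps. These four compounds show that the size of each step depends on what else the compound carries, but they do not show why, and they give no rule for any other core.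

Still open, from the compounds shown here alone, is whether a cyclopentyl ring or an open chain such as isopropyl on the nitrogen would follow either pattern. Also open, going by these compounds, is whether fluoro or methoxy in place of chloro would do so.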